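Shortening an amide side chain on two related cores

A few compounds are considered here, and "the series" means these few. Any claim that something is new, unique, unknown or untested is made for them only; others in the source may bear on it.

Three compounds have been measured in a physicochemical assay for lipophilicity, read by HPLC, measured as chromatographic lipophilicity, at pH 7.4; a higher number here means a more lipophilic compound, a lower number a more polar compound:

compound 1 `CCC(=O)NCCCO[C@H]1[C@H](C)O[C@@H](O[C@H]2[C@H](C)[C@@H](O[C@@H]3O[C@H](C)C[C@H](N(C)C)[C@H]3O)[C@](C)(O)C[C@@H](C)CN(C)[C@H](C)[C@@H](O)[C@](C)(O)[C@@H](CC)OC(=O)[C@@H]2C)C[C@@]1(C)OC` gives 2.54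
compound 2 `CCCCCCCC(=O)NCCCO[C@H]1[C@H](C)O[C@@H](O[C@H]2[C@H](C)[C@@H](O[C@@H]3O[C@H](C)C[C@H](N(C)C)[C@H]3O)[C@](C)(O)C[C@@H](C)CN(C)[C@H](C)[C@@H](O)[C@](C)(O)[C@@H](CC)OC(=O)[C@@H]2C)C[C@@]1(C)OC` gives 4.1
compound 3 `CCCCCCCC(=O)NCCCN1C[C@H](C)C[C@@](C)(O)[C@H](O[C@@H]2O[C@H](C)C[C@H](N(C)C)[C@H]2O)[C@@H](C)[C@H](O[C@H]2C[C@@](C)(OC)[C@@H](O)[C@H](C)O2)[C@@H](C)C(=O)O[C@H](CC)[C@@](C)(O)[C@H](O)[C@H]1C` gives 3.74

Compound 2 and compound 1 share one core and differ in a single place (hydrogen in place of pentyl on a saturated chain carbon, two bonds along the chain from a carbonyl carbon). That change produced a number 1.56 log units lower from compound 2 to compound 1 (beyond the scatter). Compound 3 carries the same heptylcarbonyl-capped chain on another core; the difference between the two cores is not broken down here. In this assay compound 3 stands between the other two, higher than compound 1 and lower than compound 2, both gaps beyond the scatter.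

Compound 4 `CCC(=O)NCCCN1C[C@H](C)C[C@@](C)(O)[C@H](O[C@@H]2O[C@H](C)C[C@H](N(C)C)[C@H]2O)[C@@H](C)[C@H](O[C@H]2C[C@@](C)(OC)[C@@H](O)[C@H](C)O2)[C@@H](C)C(=O)O[C@H](CC)[C@@](C)(O)[C@H](O)[C@H]1C` has not yet been measured. Among the compounds with values here, it differs from compound 3 in one place (hydrogen in place of pentyl on a saturated chain carbon, two bonds along the chain from a carbonyl carbon), which is the same change, at the same place, as the one from compound 2 to compound 1. Because the step already seen was a number 1.56 log units lower from compound 2 to compound 1 (beyond the scatter), the expected step is a number 1.54 log units lower from compound 3 to compound 4 (beyond the scatter). Compound 4 is therefore estimated at 2.2, with a likely range from 1.7 to 2.7.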

Compound 4, distribution coefficient: 1.86
The estimate for compound 4 lay 0.34 log units above the measured number; the range from low to high includes it.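

In this assay the change from heptylcarbonyl to propanoyl gave a number 1.88 log units lower from compound 3 to compound 4 (beyond the scatter) and, on the other core, a number 1.56 log units lower from compound 2 to compound 1 (beyond the scatter) in the same direction, both steps large and beyond the scatter. Within the data shown here, this shows that replacing pentyl with hydrogen, on a saturated chain carbon, two bonds along the chain from a carbonyl carbon, carried over from one core to the other in direction and rough size, but with only one pair on each core it does not show that the step would hold on any further core. Nothing measured here accounts for the size of the step on either core.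

The compounds shown leave open how the number moves for a chain of another length, such as butanoyl or a longer chain than heptylcarbonyl. They also leave open whether the step would look the same if an amine or a carboxylic acid stood at the end of the chain.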